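The source may hold more compounds than are shown below. What is called first, only, known or untested is meant among the compounds shown, and "the series" means these compounds.

Measured compounds in a functional assay on HT-1080 cells (Homo sapiens), read by transwell migration, with a stated time of 24 h, tested at 0.1 uM; a lower number here means a stronger effect, a higher number a weaker effect of the compound at the concentration tested:
compound 1 `CC(=O)OCc1ccc2oc(=O)c(C(=O)Oc3cccc(Cl)c3)cc2c1`: 95.2%
compound 2 `CC(=O)OCc1ccc2oc(=O)c(C(=O)Oc3cccc(Br)c3)cc2c1`: 39.5%
compound 3 `CCC(=O)OCc1ccc2oc(=O)c(C(=O)Oc3cccc(Br)c3)cc2c1`: 84.4%

Compound 3 stands second highest of the three numbers; the nearest is compound 1, higher by a margin beyond the scatter, and the furthest is compound 2, well below it. Compound 4 `CCCC(=O)OCc1ccc2oc(=O)c(C(=O)Oc3cccc(Br)c3)cc2c1` differs from compound 3 by methyl in place of hydrogen on a saturated chain carbon, two bonds along the chain from a carbonyl carbon.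

Going by the values given here, of the two measured steps, only one bears on this change. The step of a number 44.9 percentage points higher from compound 2 to compound 3 (beyond the scatter) is the same kind of change cut one bond further in: methyl in place of hydrogen on the saturated chain carbon bound to the carbonyl carbon, and it moved the number up strongly. The step of a number 55.7 percentage points lower from compound 1 to compound 2 (beyond the scatter) concerns the halogen on the aromatic carbon and says nothing about the chain. One step is a thin basis, and compound 3 already reads high, so a further rise is expected but a modest one, a number 4.6 percentage points higher from compound 3 to compound 4 (within the scatter). Compound 4 is estimated at 89%, within 72% to 102%.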

Compound 4, a percentage reported as activity, at one concentration (the size of the read-out at that concentration, not a potency): 88.6%
For compound 4 the middle estimate is 0.4 percentage points above the measured one, within the range that was stated.
By their numbers in this assay, from the lowest: compound 2; then compounds 3, 4 and 1 (each within the scatter of the next, the first and the last beyond it).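

In this assay the second added methyl gives a number 4.2 percentage points higher from compound 3 to compound 4 (within the scatter) and so, at a saturated chain carbon two bonds along the chain from a carbonyl carbon, this change does not repeat the large step seen one carbon closer to the carbonyl. Read over the whole chain, ethyl in place of hydrogen on the saturated chain carbon bound to a carbonyl carbon gives a number 49.1 percentage points higher from compound 2 to compound 4 (beyond the scatter) and so the large rise survives at this length and is not reversed by the further methyl. Nothing at hand explains why a large step is followed by one this small.

Going by these compounds, whether a longer chain, a branched chain or a terminal amine on this chain would leave the number where it stands remains open. Also open, on these data alone, is whether the step from chloro to bromo on the aromatic carbon holds when the chain is longer than in compound 2.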